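Dibutylamino Replacing a Branched Alkoxyalkylamine on the Shared Core

This account rests on a few compounds, and the source may have more. Where it says the series, first, only, none or still open, it means among the compounds named here.

Measured compounds:
compound 1, `CCCN(CCC)c1cc(C)nc2c(-c3ccc(N(C)C)nc3)c(C)nn12`: 4.2 nM
compound 2, `CCC(COC)Nc1cc(C)nc2c(-c3cnc(N(C)C)cc3C)c(C)nn12`: 260 nM

In an assay on CHO cells for binding affinity to corticotropin-releasing factor receptor 1 (Homo sapiens) (on this read-out higher numbers stand for weaker inhibition and lower numbers for stronger inhibition), compound 1 gives 4.2 nM, while compound 2 gives 260 nM, the higher of the two numbers and the weaker binder by a margin beyond the scatter. Compound 3, `CCCCN(CCCC)c1cc(C)nc2c(-c3cnc(N(C)C)cc3C)c(C)nn12`, is not yet measured. It differs from compound 2 in one place: dibutylamino in place of (1-(methoxymethyl)propyl)amino on an aromatic carbon. Among the measured compounds shown here, with only two measured compounds and no single-change step between them, the account rests on the structural change alone. The step from compound 2 to compound 3 in this assay is expected to give a lower number, beyond the scatter, with a 13-fold lower number from compound 2 to compound 3 (1.11 log units; beyond the scatter). For compound 3 the expected value in this assay is 20 nM, within 5 nM to 80 nM.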

Compound 3, inhibition constant: 4.2 nM
The estimate for compound 3 lay 4.8-fold (0.68 log units) above the measured number, outside the stated range (below it).
By their numbers in this assay, from the lowest: compounds 1 and 3 (each within the scatter of the next); then compound 2.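

In this assay, dibutylamino in place of (1-(methoxymethyl)propyl)amino gives a 62-fold lower number from compound 2 to compound 3 (1.79 log units; beyond the scatter), the first single-change step available here. It shows that this position, on an aromatic carbon next to the ring nitrogen, is sensitive to the choice of amino group, and that a group without a hydrogen-bond donor is accepted there. Nothing measured here accounts for the size of this step.

The compounds shown do not separate the loss of the amine hydrogen from the loss of the ether oxygen or the change in chain. A bis(2-methoxyethyl)amino group or a butylamino group on the same core would bear on that question.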